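Changing the Aryl Group on the Shared Core

This account rests on a few compounds, and the source may have more. Where it says the series, first, only, none or still open, it means among the compounds named here.

Measured so far:
compound 1 `Oc1cc(C(F)(F)F)ccc1-c1nc(-c2ccccc2O)n(-c2ccc(I)cc2)n1`: 70.1%
compound 2 `Oc1cc(C(F)(F)F)ccc1-c1nc(-c2ccccc2O)n(-c2ccc(OC(F)(F)F)cc2)n1`: 65.5%

Going by the values given here, in a functional assay on PC-12 cells (Rattus norvegicus) for cytotoxicity, read by MTT assay, with stated times of 2 h and 24 h, tested at 1 uM (on this read-out higher numbers stand for a stronger effect at the one concentration tested and lower numbers for a weaker effect), compound 1 gives 70.1%, and the only other measured compound, compound 2, gives a number that cannot be told apart from it: a number 4.6 percentage points lower from compound 1 to compound 2 (within the scatter). Compound 3 `Oc1cc(C(F)(F)F)ccc1-c1nc(-c2ccccc2O)n(-c2cc(F)cc(F)c2)n1` differs from compound 1 by 3,5-difluorophenyl in place of 4-iodophenyl on an aromatic nitrogen. Among the compounds with values here, the single measured step, from compound 1 to compound 2, changed the group on the same aromatic nitrogen and stayed within the scatter, so no step beyond the scatter is expected here either, a number 4.1 percentage points lower from compound 1 to compound 3 (within the scatter). Compound 3 is therefore estimated at 66% in this assay, between 52% and 78%.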

Compound 3, a percentage reported as activity, at one concentration (the size of the read-out at that concentration, not a potency): 75.5%
For compound 3 the middle estimate is 9.5 percentage points below the measured one; low and high end bracket the measured number.
By their numbers in this assay, from the lowest: compounds 2, 1 and 3 (each within the scatter of the next).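

In this assay, 3,5-difluorophenyl on the aromatic nitrogen stays within the scatter of both earlier aryl groups (a number 5.4 percentage points higher from compound 1 to compound 3 (within the scatter)) and (a number 10 percentage points higher from compound 2 to compound 3 (within the scatter)). This position has now carried three differently substituted phenyl groups, including one with two ring substituents instead of one, without any step beyond the scatter. Nothing measured here gives a reason for this result.

The compounds shown all keep a phenyl ring at this position. They leave open whether an amine, a carboxylic acid or a longer alkyl chain in its place would move the number beyond the scatter.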